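The source may report more compounds than this note shows. Statements on the series, on what has been measured and on what is new or still open speak of the compounds shown alone.

Of the compounds shown here, three of a shared core have been tested in a functional assay on B16-F10 cells (Mus musculus) for inhibition, read by MTT assay, with a stated time of 72 h; on this read-out lower numbers stand for stronger inhibition and higher numbers for weaker inhibition. Compound 1 `C#CCSc1nc(Nc2cccc(C(F)(F)F)c2)c(C#N)c(-c2ccccc2)n1` gives 61100 nM, compound 2 `N#Cc1c(Nc2ccccc2Cl)nc(SCc2cn(Cc3ccccc3Cl)nn2)nc1-c1ccccc1` gives 8350 nM, and compound 3 `N#Cc1c(Nc2ccc(Cl)cc2)nc(SCc2cn(Cc3ccccc3Cl)nn2)nc1-c1ccccc1` gives 1590 nM. Compound 3 thus stands lowest of the three numbers, with compound 2 nearest and compound 1 furthest away. Going by the values given here, the only single-point step among them is a 5.3-fold lower number from compound 2 to compound 3 (0.72 log units; beyond the scatter), and it concerns the same aromatic nitrogen that is now changed again.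

Compound 4 `Cc1cccc(Nc2nc(SCc3cn(Cc4ccccc4Cl)nn3)nc(-c3ccccc3)c2C#N)c1` differs from compound 3 by 3-methylphenyl in place of 4-chlorophenyl on a nitrogen on an aromatic ring. Among the compounds with values here, no measured pair shows this exact exchange, so the expectation rests on the modest size of the one step at this nitrogen and on the wide spread between compound 1 and compound 3, which differ in more than one place. A small to moderate rise in this assay is expected for compound 4, a 2.5-fold higher number from compound 3 to compound 4 (0.40 log units; beyond the scatter), though a result within the scatter would not surprise. Compound 4 is therefore estimated at 4000 nM, with a likely range from 1200 nM to 13000 nM.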

Compound 4, half-maximal inhibitory concentration: 13500 nM
Estimate against measurement, compound 4: 3.4-fold (0.53 log units) below; measured number outside the range, above it.
By their numbers in this assay, from the lowest: compound 3; then compounds 2 and 4 (each within the scatter of the next); then compound 1.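

In this assay, placing 3-methylphenyl on this nitrogen in place of 4-chlorophenyl gives an 8.5-fold higher number from compound 3 to compound 4 (0.93 log units; beyond the scatter), whereas placing it there in place of 2-chlorophenyl gives a 1.6-fold higher number from compound 2 to compound 4 (0.21 log units; within the scatter). With the rest of the molecule held fixed, the 4-chlorophenyl of compound 3 therefore stands apart from the groups on this nitrogen in both compound 2 and compound 4, which cannot be told apart from each other. Nothing available offers a reason for this difference.

The compounds shown do not separate the effect of the chlorine from that of the place of the substituent on the phenyl ring, a question that 3-chlorophenyl and 4-methylphenyl on this nitrogen would address. On these data alone, how 4-fluorophenyl or 4-methoxyphenyl would compare with 4-chlorophenyl also stays open.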